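The compounds below may be only part of what the source reports. "The series", "measured", "known", "first", "only" and "open" are said of these compounds alone.

Among the compounds with values here, compound 2 `O=C(/C=C/C1=Cc2ccccc2OC1)c1ccc(Cl)cc1` stands second highest of the three numbers measured so far, giving 56.1% in a functional assay on the whole organism for inhibition, with Mus musculus as the target, with a stated time of 1 h, at a dose of 30 mg/kg by the intraperitoneal route; a higher number here means more inhibition at the dose given (going by the name of the read-out), a lower number less inhibition. Its nearest neighbour is compound 3 `O=C(/C=C/C1=Cc2ccccc2OC1)c1ccc(Cl)cc1Cl` at 53.3%, the step of a number 2.8 percentage points lower from compound 2 to compound 3 (within the scatter) lying within the scatter; the furthest is compound 1 `O=C(/C=C/C1=Cc2ccccc2OC1)c1ccccc1F` at 64.4%, and the step of a number 8.3 percentage points lower from compound 1 to compound 2 (within the scatter) likewise stays within the scatter. Compound 4 `O=C(/C=C/C1=Cc2ccccc2OC1)c1ccc([N+](=O)[O-])cc1` differs from compound 2 by nitro in place of chloro on an aromatic carbon. Both measured steps alter the substitution of the aryl ring on the carbonyl and neither moves the inhibition beyond the scatter, though none involves a nitro group. The expected step in this assay is therefore a number 1.1 percentage points lower from compound 2 to compound 4 (within the scatter), none beyond the scatter. Compound 4 is estimated at 55%, within a range from 40% to 70%.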

Compound 4, a percentage reported as inhibition, in the whole organism at one dose (the size of the read-out at that dose, not a potency): 50.8%
Compound 4: the middle estimate sits 4.2 percentage points above what was measured, and the stated range covers the measured number.
By their numbers in this assay, from the lowest: compounds 4, 3, 2 and 1 (each within the scatter of the next, the first and the last beyond it).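

Exchanging chloro for nitro on the aromatic carbon para to a large group gives, in this assay, a number 5.3 percentage points lower from compound 2 to compound 4 (within the scatter). This position therefore accepts a larger group that carries hydrogen-bond acceptors, where chloro has none, without the inhibition moving beyond the scatter. Nothing measured here explains the size of this step. The compounds shown leave open whether an amine or a carboxylic acid at this same position would also keep the inhibition within the scatter of compound 2. They also leave open what a longer chain there would do.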